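The compounds below may be only part of what the source reports. "The series", "measured", "known", "first", "only" and "open" are said of these compounds alone.

In a functional assay on HepG2 cells (Homo sapiens) for cytotoxicity, read by MTT assay, with a stated time of 48 h (on this read-out lower numbers stand for stronger inhibition and higher numbers for weaker inhibition), compound 1 (`CC1=NN(C(=O)c2ccc(C)cc2)C(c2ccccc2O)C1`) gives 11300 nM and compound 2 (`CC1=NN(C(=O)CCl)C(c2cc(Br)ccc2O)C1`) gives 16300 nM, two values within the usual scatter of each other. Compound 3 (`CCC(=O)N1N=C(C)CC1c1cc(Br)ccc1O`) is recorded as "not active" (no number reported), so it has no number and no exact place on the scale. Compound 4 is `CC1=NN(C(=O)c2ccc(C)cc2)C(c2cc(Br)ccc2O)C1`. The change to follow is 4-methylphenyl in place of ethyl on a carbonyl carbon, with 4-methylphenyl in place of ethyl on a carbonyl carbon. Among the compounds with values here, no measured pair isolates this change. A move in this assay from no number to a measurable value, towards stronger inhibition, is expected. Within the data shown here, the only support is compound 1, which also carries 4-methylphenyl on a carbonyl carbon and gives 11300 nM. For compound 4 the estimated value is 12000 nM, with an expected range of 5000 nM to 30000 nM.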

Compound 4, half-maximal inhibitory concentration: 23200 nM
Compound 4: the middle estimate sits 1.9-fold (0.29 log units) below what was measured; low and high end bracket the measured number.
By their numbers in this assay, from the lowest: compounds 1, 2 and 4 (each within the scatter of the next, the first and the last beyond it).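

On the carbonyl carbon, 4-methylphenyl and chloromethyl are not separated in this assay, with a 1.4-fold higher number from compound 2 to compound 4 (0.15 log units; within the scatter), while ethyl in compound 3 has no number, so steps to compound 3 cannot be read. With 4-methylphenyl held on the carbonyl carbon, bromo in place of hydrogen on an aromatic carbon gives a 2.1-fold higher number from compound 1 to compound 4 (0.31 log units; beyond the scatter), a modest move towards weaker inhibition. No measurement shown accounts for either result. Open, going by these compounds, is whether an amine or a longer chain on the carbonyl carbon gives a number, and whether chloro in place of bromo shifts the value.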